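Carbonyl substituent variation: amide, thioester, ester

The source may hold more compounds than are shown below. What is called first, only, known or untested is meant among the compounds shown, and "the series" means these compounds.

Measured compounds:
compound 1 `CC1=C(C(=O)NC(C)C)C(c2cccs2)NC(=O)N1`: 1%
compound 2 `CC1=C(C(=O)SC(C)C)C(c2cccs2)NC(=O)N1`: 1%

In an assay on membranes from HeLa cells for displacement of a labelled ligand from adenosine receptor A3 (Homo sapiens), read by scintillation counting, with a stated time of 180 min, tested at 1 uM (on this read-out lower numbers stand for less inhibition and higher numbers for more inhibition at the one concentration tested (going by the name of the read-out)), compound 1 gives 1%. In this assay compound 2 gives 1%. Among the measured compounds shown here, the single step measured so far, no change at the digits printed from compound 1 to compound 2 (within the scatter), concerns the substituent on the carbonyl carbon and leaves the read-out where it was. Compound 2 therefore stands level with compound 1 at the digits shown, and no separation within the series is visible.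

The next compound, compound 3 `CCC(CC)OC(=O)C1=C(C)NC(=O)NC1c1cccs1`, differs from compound 2 only at the same carbonyl carbon: (pentan-3-yl)oxy in place of isopropylsulfanyl on a carbonyl carbon. For the measured compounds named here, the one step that bears on this change is the exchange at that carbonyl carbon from compound 1 to compound 2, and it stayed within the scatter. Nothing measured suggests that a further exchange of the group on this carbonyl carbon moves the read-out, so the expected step of a number 1 percentage points higher from compound 2 to compound 3 (within the scatter) is none beyond the scatter. Compound 3 is estimated at 2%, with the expected range running from 0% to 12%.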

Compound 3, a percentage reported as inhibition, at one concentration (the size of the read-out at that concentration, not a potency): 1%
Compound 3: middle estimate off by 1 percentage points, on the high side; low and high end bracket the measured number.
By their numbers in this assay, from the lowest: compounds 1, 2 and 3 (each within the scatter of the next).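

In this assay, exchanging isopropylsulfanyl for (pentan-3-yl)oxy on a carbonyl carbon gives no change at the digits printed from compound 2 to compound 3 (within the scatter), and exchanging isopropylamino for the same group gives no change at the digits printed from compound 1 to compound 3 (within the scatter). The ester therefore joins the amide and the thioester within the scatter, so this read-out does not separate the three, even when the atom attached to the carbonyl carbon and the alkyl group attached to that atom both differ. No measurement at hand accounts for this flat result.

The compounds shown leave open whether any group on this carbonyl carbon can raise the read-out at all, for example a carboxylic acid, a tertiary amine or a longer chain on the ester oxygen. Changes elsewhere on the shared core also remain open, as all three compounds differ only at this carbonyl carbon.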